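The source may hold more compounds than are shown below. What is called first, only, known or untested is meant among the compounds shown, and "the series" means these compounds.

Within the data shown here, compound 2 `COc1ccc(C(=O)/C=C/c2cc(-c3cc(OC)c(OC)c(OC)c3)n[nH]2)cc1` stands at the higher of the two numbers so far: in a functional assay on BT-549 cells (Homo sapiens) for inhibition, read by sulforhodamine B assay, with a stated time of 48 h (on this read-out higher numbers stand for weaker inhibition of growth and lower numbers for stronger inhibition of growth), compound 2 gives 3860 nM, and compound 1 `COc1cc(-c2cc(/C=C/C(=O)c3ccc(N)cc3)[nH]n2)cc(OC)c1OC` gives 2820 nM, the gap being a 1.4-fold higher number from compound 1 to compound 2 (0.14 log units; within the scatter). Compound 3 `COc1cc(-c2cc(/C=C/C(=O)c3ccc(F)c(F)c3)[nH]n2)cc(OC)c1OC` carries 3,4-difluorophenyl in place of 4-methoxyphenyl on a carbonyl carbon. Among the measured compounds shown here, the only measured step sits at that same carbonyl-attached ring and changed the number within the scatter; no measured step covers a fluorinated ring, so the expected step of a 1.0-fold higher number from compound 2 to compound 3 (0.02 log units; within the scatter) in this assay is none beyond the scatter. Compound 3 is therefore expected at 4000 nM, with a range from 1400 nM to 11000 nM.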

Compound 3, concentration for total growth inhibition: 19300 nM
The estimate for compound 3 lay 4.8-fold (0.68 log units) below the measured number; measured number above the stated range.
By their numbers in this assay, from the lowest: compounds 1 and 2 (each within the scatter of the next); then compound 3.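

In this assay, the group on a carbonyl carbon proves sensitive to replacement: 3,4-difluorophenyl in place of 4-methoxyphenyl gives (a 5.0-fold higher number from compound 2 to compound 3 (0.70 log units; beyond the scatter)), and in place of 4-aminophenyl gives (a 6.8-fold higher number from compound 1 to compound 3 (0.84 log units; beyond the scatter)). Growth inhibition therefore weakens with this ring, whereas the earlier swap between the amino and methoxy groups stayed within the scatter. Nothing at hand explains the shift. Still open, going by these compounds, is whether 4-fluorophenyl or 3-fluorophenyl alone gives the same weakening, and where a 4-hydroxyphenyl or 4-chlorophenyl group would stand.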